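The compounds below may be only part of what the source reports. "The series", "measured", "known", "first", "only" and "open" are said of these compounds alone.

Working notes on the series. In a functional assay on GC3/MTK- cells (Homo sapiens) for inhibition (on this read-out lower numbers stand for stronger inhibition and higher numbers for weaker inhibition), compound 1 (`C#CCN(Cc1ccc2nc(C)nc(O)c2c1)c1ccccc1`) gives > 10700 nM as a limit of the assay and not a number. Compound 2 (`C#CCN(Cc1ccc2nc(C)nc(O)c2c1)c1cccc(C(F)(F)F)c1`) gives > 4300 nM and this too is only a limit. Going by the values given here, compound 2 therefore has no number to stand on, and the one other value shown is also a limit.

The next change leads to compound 3 (`C#CCN(Cc1ccc2nc(C)nc(O)c2c1)c1cccc(I)c1`), with iodo in place of trifluoromethyl on an aromatic carbon, meta to a large group. Among the compounds with values here, one measured step bears on this group, the exchange of hydrogen for trifluoromethyl. That step, a step that the two limits leave unreadable from compound 1 to compound 2 in size, cannot be read, so it offers no size or direction to carry over.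

Only a modest change is expected in this assay, with no firm direction, and the estimated move is a step that the limit leaves unreadable from compound 2 to compound 3 at best loosely defined. For compound 3 the expected value is 5000 nM within an estimated range of 1500 nM to 15000 nM in this read-out, and a result given only as a limit would not be surprising.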

Compound 3, half-maximal inhibitory concentration: > 5300 nM
Compound 3: a limit, no number (the forecaster's own chance of this, stated with the estimate: 55%); middle value at least 1.0-fold (0.02 log units) from the limit.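

No step can be read among compound 1, compound 2 and compound 3, since this assay gives only limits of the assay for all three and no number. What the compounds shown leave open is whether any of the three aromatic substituents, hydrogen, trifluoromethyl or iodo, changes inhibition in this read-out at all.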